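The source may hold more compounds than are shown below. What is called first, only, known or untested is meant among the compounds shown, and "the series" means these compounds.

All three measured compounds were tested in a functional assay on HCT-116 cells (Homo sapiens) for antiproliferative activity, read by MTT assay, with a stated time of 72 h; on this read-out lower numbers stand for stronger inhibition and higher numbers for weaker inhibition:

compound 1, `CN(C(=O)c1ccccc1)c1ccc2[nH]c(-c3n[nH]c4ccccc34)cc2n1`, gives 10600 nM
compound 2, `COc1cccc(C(=O)N(C)c2ccc3[nH]c(-c4n[nH]c5ccccc45)cc3n2)c1`, gives 14200 nM
compound 3, `COc1ccc(S(=O)(=O)N(C)c2ccc3[nH]c(-c4n[nH]c5ccccc45)cc3n2)cc1`, gives 22400 nM

Compound 1 and compound 2 share one core and differ in a single place: methoxy in place of hydrogen on an aromatic carbon. In this assay this change made a 1.3-fold higher number from compound 1 to compound 2 (0.13 log units; within the scatter), so the two numbers cannot be told apart. Compound 3 carries a different core; how its core differs from that of compound 1 is not broken down here. The number for compound 3 lies within the usual scatter of the number for compound 2, while the gap to the number for compound 1 is beyond it.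

Compound 4, `COc1ccc(S(=O)(=O)N(C)c2ccc3[nH]c(-c4n[nH]c5ccccc45)cc3n2)cc1OC`, has not yet been measured. It differs from compound 3 by methoxy in place of hydrogen on an aromatic carbon. Going by the values given here, this is the same kind of change as the one from compound 1 to compound 2, though not the same: in compound 2 the incoming methoxy sits meta to a large group, whereas in compound 4 it sits ortho to a methoxy group and meta to a large group. The step from compound 3 to compound 4 in this assay is expected to be a 1.2-fold higher number from compound 3 to compound 4 (0.06 log units; within the scatter), an expectation that rests on the measured step of a 1.3-fold higher number from compound 1 to compound 2 (0.13 log units; within the scatter) produced by the same kind of change, and on that single example alone. Compound 4 is therefore estimated at 26000 nM, with a likely range from 12000 nM to 55000 nM.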

Compound 4, half-maximal inhibitory concentration: 16700 nM
Beside the measured number, compound 4's estimate is 1.6-fold (0.19 log units) above it, within the range that was stated.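

In this assay the methoxy that turns 4-methoxyphenyl into 3,4-dimethoxyphenyl gives a 1.3-fold lower number from compound 3 to compound 4 (0.13 log units; within the scatter) and so leaves the two numbers impossible to tell apart. The same kind of change on the core of compound 1 also left its two numbers impossible to tell apart, and the two steps cannot be separated from each other: the same change on two cores in this assay, a 1.3-fold higher number (0.13 log units; within the scatter) from compound 1 to compound 2 and a 1.3-fold lower number (0.13 log units; within the scatter) from compound 3 to compound 4, 1.8-fold (0.25 log units) apart, within the scatter of two such steps. This shows that, in the two cases available, adding a methoxy to the aromatic ring made no measurable difference on either core, so the outcome carried over in that limited sense, but it does not show that the change would be equally silent on any other core in this series, since two small steps within the scatter offer very little to compare and the methoxy does not stand in the same surroundings in the two cases.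

The compounds shown leave open whether a different group in this place, such as an amine, a carboxylic acid or a longer chain like ethoxy, would shift the number beyond the scatter. They also leave open what a methoxy would do at other places on the same ring.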